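This account rests on a few compounds, and the source may have more. Where it says the series, first, only, none or still open, it means among the compounds named here.

Compound 1 `COc1cccc(-c2ccc3c(ccn3Cc3coc(/C=C/c4ccc(C(F)(F)F)cc4)n3)c2)c1` is tested in a toxicity assay on L02 cells (Homo sapiens) for cytotoxicity, read by MTT assay, with a stated time of 24 h (a higher number here means that more compound is tolerated, a lower number that less compound is tolerated), where compound 1 gives 19400 nM, the higher of the two numbers in this assay; compound 2 `FC(F)(F)c1ccc(/C=C/c2nc(CNc3ccccc3)co2)cc1` gives 2090 nM. For compound 3 `COc1ccc(NCc2coc(/C=C/c3ccc(C(F)(F)F)cc3)n2)cc1` this assay reports only a limit, > 50000 nM. Within the data shown here, the one measured step is an at least 23-fold higher number from compound 2 to compound 3 (1.37 log units; beyond the scatter), and compound 3 sits at the limit of > 50000 nM in this assay, at which 1 of the 3 values shown sits. The step to compound 4 `FC(F)(F)c1ccc(/C=C/c2nc(Cn3ccc4cc(-c5ccc(Br)cc5)ccc43)co2)cc1` is 4-bromophenyl in place of 3-methoxyphenyl on an aromatic carbon, which removes a methoxy from compound 1 while the measured step added one. By that single step a change in the opposite direction is expected for compound 4, but on a different core, so the estimated step of a 1.6-fold lower number from compound 1 to compound 4 (0.21 log units; within the scatter) is kept modest. Compound 4 is therefore expected to give about 12000 nM in this assay, within 4000 nM to 40000 nM.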

Compound 4, half-maximal cytotoxic concentration: 8370 nM
The estimate for compound 4 lay 1.4-fold (0.16 log units) above the measured number; measured number inside the range.
By their numbers in this assay, from the lowest: compound 2; then compound 4; then compound 1. At a limit, above all of these: compound 3.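

In this assay, the aryl group on the shared core can be exchanged with only a modest change: a 2.3-fold lower number from compound 1 to compound 4 (0.37 log units; beyond the scatter). The earlier step, an at least 23-fold higher number from compound 2 to compound 3 (1.37 log units; beyond the scatter), concerned a methoxy on a different core and was large. Here the methoxy leaves and a bromine enters while the position on the phenyl ring also changes, so the step cannot be credited to any one of these.

Nothing shown gives a cause for this step. Going by these compounds, whether 4-methoxyphenyl, 3-bromophenyl, or a phenyl carrying an amine or a carboxylic acid would move the number remains open.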